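This account rests on a few compounds, and the source may have more. Where it says the series, first, only, none or still open, it means among the compounds named here.

Compound 1 `Cc1ccc(-c2cs/c(=N/NC(=O)CSc3nnnn3-c3ccccc3)n2-c2ccccc2)cc1` gives 38.8% in a functional assay on C6 cells (Rattus norvegicus) for cytotoxicity, read by MTT assay, with a stated time of 24 h, tested at 25 ug/mL; a lower number here means a stronger effect, a higher number a weaker effect of the compound at the concentration tested.
Compound 2 `Cc1ccc(-c2cs/c(=N/NC(=O)CSc3nncn3C)n2-c2ccccc2)cc1` gives 70.7% in this assay.

In this assay compound 2 stands highest of the two numbers, with compound 1 the nearest. Among the measured compounds shown here, the only measured step is a number 31.9 percentage points higher from compound 1 to compound 2 (beyond the scatter), a change of the group on the sulfur. Compound 3 `Cn1cnnc1SCC(=O)N/N=c1/scc(-c2ccc(C#N)cc2)n1-c1ccccc1` differs from compound 2 at another place: cyano in place of methyl on an aromatic carbon. For the measured compounds named here, no measured step touches this position, so the step from compound 1 to compound 2 does not bear on it. Without a precedent, no change beyond the scatter is expected, and the estimated step is a number 0.7 percentage points lower from compound 2 to compound 3 (within the scatter). Compound 3 is therefore expected to give 70%, in the range 50% to 90%.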

Compound 3, a percentage reported as activity, at one concentration (the size of the read-out at that concentration, not a potency): 58.8%
Estimate against measurement, compound 3: 11.2 percentage points above, within the range that was stated.
By their numbers in this assay, from the lowest: compound 1; then compound 3; then compound 2.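

The position on the six-membered aromatic ring is not silent in this assay: 4-methylphenyl to 4-cyanophenyl gives a number 11.9 percentage points lower from compound 2 to compound 3 (beyond the scatter), so the cyano compound has the stronger effect of this pair at the concentration tested. Among the compounds shown here, this is the first read on this position, and it holds with only the 4-methyl-4H-1,2,4-triazol-3-yl group on the sulfur. Nothing available explains the step.

Open: whether an amine or a carboxylic acid in the same place moves the read-out in the same direction, and whether cyano in place of methyl gives a similar step with 1-phenyl-1H-tetrazol-5-yl on the sulfur.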